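The source may report more compounds than this note shows. Statements on the series, on what has been measured and on what is new or still open speak of the compounds shown alone.

Three compounds have been measured in a functional assay on T98G cells (Homo sapiens) for cytotoxicity, read by MTT assay, with a stated time of 48 h; a lower number here means a stronger inhibitor, a higher number a weaker inhibitor:
Compound 1, `CC(=NNC(=S)Nc1cccc(I)c1)c1ccccn1`, gives 61 nM.
Compound 2, `CC(=NNC(=S)Nc1ccccc1)c1ccccn1`, gives 6.8 nM.
Compound 3, `C/C(=N\NC(=S)Nc1ccccc1)c1ccccn1`, gives 6.81 nM.

Compound 2 and compound 3 are built from the same atoms and bonds; what separates them is only how they are drawn: the two compounds have the same atoms and bonds; at least one stereo element is drawn with a configuration in one of them and without one in the other: 1 of 1 stereo elements differ; a double bond is drawn without a configuration in compound 2 and E in compound 3. Their values lie together, as the step of a 1.0-fold higher number from compound 2 to compound 3 (0.00 log units; within the scatter) shows, and this fits (the fact that one of compounds 2 and 3 is drawn with a defined configuration and the other without, at the place where they differ). Compound 1 differs from compound 2 by iodo in place of hydrogen on an aromatic carbon, and that change made the step of a 9.0-fold higher number from compound 2 to compound 1 (0.95 log units; beyond the scatter).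

Compound 4, `C/C(=N\NC(=S)Nc1cccc(I)c1)c1ccccn1`, has not yet been measured in this assay. It differs from compound 3 by iodo in place of hydrogen on an aromatic carbon. This is the same change as the one from compound 2 to compound 1, made at the same place, and it occurs twice among these four compounds. Compound 2 and compound 3 give values within the scatter of each other, so the measured step of a 9.0-fold higher number from compound 2 to compound 1 (0.95 log units; beyond the scatter) is the natural guide for what the same change should do starting from compound 3. The expected step is a 9.0-fold higher number from compound 3 to compound 4 (0.95 log units; beyond the scatter), resting on the measured step of a 9.0-fold higher number from compound 2 to compound 1 (0.95 log units; beyond the scatter). Compound 4 is therefore estimated at 61 nM, with a likely range from 25 nM to 150 nM.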

Compound 4, half-maximal inhibitory concentration: 61 nM
Compound 4: middle estimate and measured number agree at the digits printed, within the range that was stated.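

In this assay, iodo in place of hydrogen on the aromatic ring gives a 9.0-fold higher number from compound 3 to compound 4 (0.95 log units; beyond the scatter), and this matches the earlier step on the other core: the same change on two cores in this assay, a 9.0-fold higher number (0.95 log units; beyond the scatter) from compound 2 to compound 1 and a 9.0-fold higher number (0.95 log units; beyond the scatter) from compound 3 to compound 4, 1.0-fold (0.00 log units) apart, within the scatter of two such steps. The two iodo compounds also sit together, with no change at the digits printed from compound 1 to compound 4 (within the scatter), and they differ only in how one double bond is drawn: the fact that one of compounds 1 and 4 is drawn with a defined configuration and the other without, at the place where they differ. This shows that the loss of potency from adding iodo repeats across these two pairs, but it is a mild test of transfer, since the two cores have the same atoms and bonds and differ only in whether that double bond has a drawn configuration, so it does not show that the step would hold on a core with different atoms and bonds, nor does it say why the number rises.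

The compounds shown leave open whether another group on the same aromatic carbon, such as fluoro, a methoxy group or an amine, would move the number as far as iodo does. They also leave open whether iodo would have a similar effect at another carbon of that ring.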